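The source may hold more compounds than are shown below. What is called first, only, known or untested is meant among the compounds shown, and "the series" means these compounds.

Compound 1 `CC/C(=C(/c1ccc(/C=C/C(=O)O)cc1)c1ccc2[nH]nc(C)c2c1)c1ccccc1`: in a functional assay on MCF7 cells (Homo sapiens) for cytotoxicity, read by CellTiter-Glo, with a stated time of 5 days (a higher number here means a weaker inhibitor, a lower number a stronger inhibitor), compound 1 gives > 1000 nM, which is a limit of the assay rather than a number.
Compound 2 `CC/C(=C(/c1ccc(/C=C/C(=O)O)cc1)c1ccc2[nH]ncc2c1C)c1ccccc1`: compound 2 gives 50 nM.
Compound 3 `CC/C(=C(/c1ccc(/C=C/C(=O)O)cc1)c1ccc2[nH]nc(F)c2c1)c1ccccc1`: compound 3 gives 5 nM.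

Compound 3 stands lowest of the two numbers shown; its nearest neighbour is compound 2, with a 10-fold lower number from compound 2 to compound 3 (1.00 log units; beyond the scatter). Compound 4 `CC/C(=C(/c1ccc(/C=C/C(=O)O)cc1)c1cc(Cl)c2[nH]ncc2c1)c1ccccc1` differs from compound 3 in one place: 7-chloro-1H-indazol-5-yl in place of 3-fluoro-1H-indazol-5-yl on a double-bonded chain carbon bound to an aromatic carbon and a double-bonded chain carbon. Among the compounds with values here, two measured steps bear on this change. One swapped a halogen for a methyl at one ring position, an at least 200-fold lower number from compound 1 to compound 3 (2.30 log units; beyond the scatter); the other moved a group to a different ring position, a 10-fold lower number from compound 2 to compound 3 (1.00 log units; beyond the scatter). Both shifted this assay beyond the scatter, so moving a halogen to a new ring position is expected to shift the number as well, most likely upward from the lowest value shown. Compound 4 is therefore expected to give 30 nM, within 5 nM to 200 nM, an estimated step of a 6.0-fold higher number from compound 3 to compound 4 (0.78 log units; beyond the scatter).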

Compound 4, half-maximal inhibitory concentration: 56 nM
Beside the measured number, compound 4's estimate is 1.9-fold (0.27 log units) below it, within the range that was stated.
By their numbers in this assay, from the lowest: compound 3; then compounds 2 and 4 (each within the scatter of the next). At a limit, above all of these: compound 1.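

The 7-chloro-1H-indazol-5-yl group shows that a halogen on this ring does not by itself give the lowest number in this assay: an 11-fold higher number from compound 3 to compound 4 (1.05 log units; beyond the scatter). Against 4-methyl-1H-indazol-5-yl it gives no real difference, a 1.1-fold higher number from compound 2 to compound 4 (0.05 log units; within the scatter). It still improves on 3-methyl-1H-indazol-5-yl, an at least 17-fold lower number from compound 1 to compound 4 (1.25 log units; beyond the scatter), a step that rests on a limit of the assay and not on a number.

The change swapped the halogen and its place together, and the compounds shown do not separate the two. On these data alone, how a 3-chloro-1H-indazol-5-yl or 7-fluoro-1H-indazol-5-yl group would read stays open.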